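From a 4-bromophenyl to a (cyclohexylmethyl)amino group

A few compounds are considered here, and "the series" means these few. Any claim that something is new, unique, unknown or untested is made for them only; others in the source may bear on it.

Of the compounds shown here, three have so far been tested in a functional assay on HeLa cells (Homo sapiens) for inhibition, read by MTT assay, with a stated time of 72 h; a higher number here means a weaker inhibitor, a lower number a stronger inhibitor. Compound 1 `O=C(Nc1ccc(Br)cc1)Nc1ccc(Nc2ncnc3[nH]ncc23)cc1` gives only a limit, > 10000 nM. Compound 2 `Cn1ncc2c(Oc3ccc(NC(=O)Nc4ccc(C(F)(F)F)cc4)cc3)ncnc21` also gives only a limit, > 10000 nM. Compound 3 `O=C(Nc1ccc(Oc2ncnc3[nH]ncc23)cc1)c1ccc(Br)cc1` likewise gives only a limit, > 10000 nM, so it has no exact position on the scale. All three readings are the same: the limit of > 10000 nM in this assay, at which 3 of the 3 values shown sit.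

Compound 4 `O=C(NCC1CCCCC1)Nc1ccc(Oc2ncnc3[nH]ncc23)cc1` departs from compound 3 at a single place, on a carbonyl carbon: (cyclohexylmethyl)amino in place of 4-bromophenyl on a carbonyl carbon. A six-membered aromatic ring of carbon leaves, and a six-membered non-aromatic ring of carbon enters along with a hydrogen-bond donor.

Among the measured compounds shown here, no measured step between two compounds is available in this assay to serve as a guide. The expectation therefore rests on compound 3, whose limit is > 10000 nM. No change beyond the scatter is expected, in either direction, and the expected step is a number no higher from compound 3 to compound 4 (the limit leaves the size open). For compound 4 the estimated half-maximal inhibitory concentration is 10000 nM, with an expected range of 4000 nM to 25000 nM.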

Compound 4, half-maximal inhibitory concentration: > 10000 nM
Compound 4: a limit, no number; the forecaster's own chance of this, stated with the estimate: 75%; the middle value lies on the limit itself.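

Compound 4 gives only a limit in this assay, as compound 3 does, so no step can be read from compound 3 to compound 4: the limit of > 10000 nM in this assay, at which 4 of the 4 values shown sit. The compounds shown leave open whether any of these structural changes alters inhibition in this assay.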